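Truncation of the acetylphenoxy arm in a sulfonamide series

This account rests on a few compounds, and the source may have more. Where it says the series, first, only, none or still open, it means among the compounds named here.

Compound 1 `COc1cc2c(cc1OC)CN(S(=O)(=O)c1ccc(-n3cc(COc4ccccc4C(C)=O)nn3)cc1)CC2` carries a (2-acetylphenoxy)methyl arm on the shared core. In a functional assay on MOLT-3 cells (Homo sapiens) for cytotoxicity, read by MTT assay, with a stated time of 48 h (on this read-out lower numbers stand for stronger inhibition and higher numbers for weaker inhibition), compound 1 gives > 50 ug/mL, which is a limit of the assay rather than a number. Compound 2 `O=Cc1ccc(OCc2cn(-c3ccc(S(=O)(=O)N4CCc5ccccc5C4)cc3)nn2)cc1` bears a formyl-substituted phenoxy arm and a core without the two methoxy groups. In this assay compound 2 gives > 50 ug/mL, again a limit. Everything measured so far rests at the limit of > 50 ug/mL in this assay, at which 2 of the 2 values shown sit, so compound 1 stands on that limit and no number has been obtained for it.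

Compound 3 `COc1cc2c(cc1OC)CN(S(=O)(=O)c1ccc(-n3cc(CO)nn3)cc1)CC2` is the truncated analogue; the change from compound 1 is hydrogen in place of 2-acetylphenyl on an oxygen on a saturated carbon, so the aryl ether is cut back to a hydroxymethyl group. Among the measured compounds shown here, no step between measured compounds is available for comparison. With both measured values at the limit, nothing shows that the 2-acetylphenyl group contributes to inhibition; the step that the limit leaves unreadable from compound 1 to compound 3 is therefore expected to be none beyond the scatter, with compound 3 most likely returned as a limit once more. The estimate for compound 3 is 60 ug/mL, within a range from 20 ug/mL to 200 ug/mL.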

Compound 3, half-maximal inhibitory concentration: > 50 ug/mL
Compound 3: only a limit was reported (the forecaster's own chance of this, stated with the estimate: 80%); the middle value is on the limit's open side.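

Compound 3, like compound 1, returns only a limit and not a number, so no step can be read between them: the limit of > 50 ug/mL in this assay, at which 3 of the 3 values shown sit.

The compounds shown leave open whether any member of this series gives a number in this assay, and whether replacing 2-acetylphenyl with hydrogen changes inhibition at all.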